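Aryl amide variation on a shared benzenesulfonamide core

The compounds below may be only part of what the source reports. "The series", "measured", "known", "first", "only" and "open" are said of these compounds alone.

Three amides on one shared core have been measured in an assay on MDA-MB-231 cells for binding affinity to C-X-C chemokine receptor type 4 (Homo sapiens), read by immunofluorescence and microscopy, with stated times of 10 min and 30 min; on this read-out lower numbers stand for an effect already at smaller amounts and higher numbers for an effect only at larger amounts of compound. Compound 1 `COc1ccc(C(=O)NCc2ccc(CNS(=O)(=O)c3ccccc3)cc2)cc1` gives 1000 nM. Compound 2 `Cc1cccc(C(=O)NCc2ccc(CNS(=O)(=O)c3ccccc3)cc2)c1` gives 1000 nM, and in this assay no change at the digits printed from compound 1 to compound 2 (within the scatter). Compound 3 `Cc1ccc(C(=O)NCc2ccc(CNS(=O)(=O)c3ccccc3)cc2)cc1` gives 100 nM, the lowest number of the three; both its steps from the others are beyond the scatter, so compound 3 stands alone at the low end.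

Compound 4 `O=C(NCc1ccc(CNS(=O)(=O)c2ccccc2)cc1)c1ccccc1F` differs from compound 3 in one place: 2-fluorophenyl in place of 4-methylphenyl on a carbonyl carbon. Within the data shown here, the steps that bear on this change are the two ending at compound 3, both on the same ring at the carbonyl carbon: a 10-fold lower number from compound 1 to compound 3 (1.00 log units; beyond the scatter) and a 10-fold lower number from compound 2 to compound 3 (1.00 log units; beyond the scatter). Each shows that the group on that ring moves the number by a clear step, and compound 4 gives up the 4-methylphenyl that carries the lowest number. An upward step in this assay is therefore expected; the incoming 2-fluorophenyl has no measured counterpart here, so the expectation is set short of the shown steps. Compound 4 is expected to give 500 nM (range 150 nM to 2000 nM). The expected step is a 5.0-fold higher number from compound 3 to compound 4 (0.70 log units; beyond the scatter).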

Compound 4, effective concentration (reported as EC, without a stated level of effect): 1000 nM
Estimate against measurement, compound 4: 2.0-fold (0.30 log units) below; the range from low to high includes it.
By their numbers in this assay, from the lowest: compound 3; then compounds 1, 2 and 4 (each within the scatter of the next).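

In this assay, 2-fluorophenyl in place of 4-methylphenyl on a carbonyl carbon gives a 10-fold higher number from compound 3 to compound 4 (1.00 log units; beyond the scatter), so a third group on that carbonyl carbon now loses the low number of compound 3. Against the other two groups, the readings are no change at the digits printed from compound 2 to compound 4 (within the scatter) and no change at the digits printed from compound 1 to compound 4 (within the scatter), which places 2-fluorophenyl, 3-methylphenyl and 4-methoxyphenyl together and leaves compound 3 alone at the low end of these four amides. No measurement at hand bears on why the 4-methylphenyl stands apart.

Open, from the compounds shown here alone, is whether the low number belongs to the 4-methylphenyl alone or also appears with an ethyl group, a chlorine, an amine or a carboxylic acid on that ring. Also open is whether compound 3 keeps its place among these amides when the shared core carries a longer chain.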